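Swapping the amide-side aryl group in a dopamine D4 series

The compounds below may be only part of what the source reports. "The series", "measured", "known", "first", "only" and "open" are said of these compounds alone.

Measured compounds:
compound 1, `CCc1cccc(NC(=O)CN2CCC(c3cccc[n+]3[O-])CC2)c1`, 62%
compound 2, `Cc1cccc(NC(=O)CN2CCC(c3cccc(F)c3)CC2)c1`, 40%
compound 3, `COc1cccc(C)c1NC(=O)CN1CCC(c2cccc[n+]2[O-])CC1`, 56%

All three were tested in a functional assay on HEK293 cells for agonist activity at D(4) dopamine receptor (Homo sapiens), read by FLIPR; a higher number here means a larger maximal response, a lower number a smaller maximal response. Compound 1 gives the highest of the three numbers, 62%. Compound 3, at 56%, sits within the usual scatter of that figure, so the two cannot be told apart. Compound 2, at 40%, lies beyond the scatter below compound 1.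

Compound 4, `O=C(CN1CCC(c2cccc[n+]2[O-])CC1)Nc1ccccc1F`, has not yet been measured. It differs from compound 1 by 2-fluorophenyl in place of 3-ethylphenyl on an amide-type nitrogen. Going by the values given here, no pair of measured compounds shows this change, so its effect is unknown. For compound 4 a step of a number 7 percentage points lower from compound 1 to compound 4 (within the scatter) in this assay is expected, at most a modest fall, hardly beyond the scatter. Compound 4 is estimated at 55%, in a range from 38% to 70%.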

Compound 4, largest response reached (reported as efficacy), in percent of the reference or control that the assay uses: 63%
For compound 4 the middle estimate is 8 percentage points below the measured one; the measured number falls inside the stated range.
By their numbers in this assay, from the lowest: compound 2; then compounds 3, 1 and 4 (each within the scatter of the next).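

In this assay, 2-fluorophenyl in place of 3-ethylphenyl on the amide-type nitrogen gives a number 1 percentage points higher from compound 1 to compound 4 (within the scatter). Going by these compounds alone, this is the first direct comparison at this position, and it shows that, with the rest of compound 1 unchanged, these two aryl groups cannot be told apart by maximal response. No available evidence bears on why the response holds. Still open, as far as these compounds go, is whether an aryl group carrying a carboxylic acid or an amine would hold the response as well, or whether this position tolerates only groups like these two.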